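Adding an ethoxy group to a chloro-indazole sulfonamide

This account rests on a few compounds, and the source may have more. Where it says the series, first, only, none or still open, it means among the compounds named here.

Measured compounds:
compound 1, `COc1ccc(S(=O)(=O)Nc2cccc3[nH]nc(Cl)c23)cc1`, 500 nM;
compound 2, `CCOc1ccc(NS(=O)(=O)c2ccc(C)cc2)c2cn[nH]c12`, 43500 nM;
compound 3, `CCOc1ccc(NS(=O)(=O)c2ccc(C)cc2)c2c(Br)n[nH]c12`, 5210 nM.

In a functional assay on P388 cells (Mus musculus) for cytotoxicity, read by MTT assay, with a stated time of 72 h (on this read-out higher numbers stand for weaker inhibition and lower numbers for stronger inhibition), compound 1 gives the lowest of the three numbers; compound 3 lies above it and compound 2 furthest above. The unmeasured compound 4, `CCOc1ccc(NS(=O)(=O)c2ccc(OC)cc2)c2c(Cl)n[nH]c12`, differs from compound 1 by ethoxy in place of hydrogen on an aromatic carbon. Going by the values given here, no measured pair isolates this change. Among the compounds with values here, the only single step, an 8.3-fold lower number from compound 2 to compound 3 (0.92 log units; beyond the scatter), concerns a halogen and not the ethoxy group, so it bears on compound 4 only as a sign that substituents on this core matter. Compound 3, which carries the ethoxy group beside other changes, gives 5210 nM, above compound 1. Compound 4 is therefore expected to give 1000 nM, within 200 nM to 6000 nM, a step of a 2.0-fold higher number from compound 1 to compound 4 (0.30 log units; within the scatter) that is uncertain in direction.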

Compound 4, half-maximal inhibitory concentration: 580 nM
The estimate for compound 4 lay 1.7-fold (0.24 log units) above the measured number, within the range that was stated.
By their numbers in this assay, from the lowest: compounds 1 and 4 (each within the scatter of the next); then compound 3; then compound 2.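

In this assay, ethoxy in place of hydrogen on this aromatic carbon, para to a large group, is tolerated: a 1.2-fold higher number from compound 1 to compound 4 (0.06 log units; within the scatter) leaves the two numbers within the usual scatter of each other. The earlier compounds shown here carried the ethoxy group only alongside other changes, whereas this pair isolates it. Nothing available gives a reason for this result. Going by these compounds, whether a methoxy group, a longer chain or an amine at this position would behave alike stays open. So does whether ethoxy would be tolerated equally on a core without the chloro group.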